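Extending an Ester Chain on Two Related Cores

The source may report more compounds than this note shows. Statements on the series, on what has been measured and on what is new or still open speak of the compounds shown alone.

Compound 1 `COC(=O)C1=C(C)NC(=O)NC1c1cccs1` and compound 2 `CCCOC(=O)C1=C(C)NC(=O)NC1c1cccs1` share one core, while compound 3 `COC(=O)C1=C(C)NC(=S)NC1c1cccs1` and compound 4 `CCCOC(=O)C1=C(C)NC(=S)NC1c1cccs1` share another; the difference between the two cores is not broken down here. In an assay on membranes from HeLa cells for displacement of a labelled ligand from adenosine receptor A3 (Homo sapiens), read by scintillation counting, with a stated time of 180 min, tested at 1 uM (on this read-out higher numbers stand for more inhibition at the one concentration tested (going by the name of the read-out) and lower numbers for less inhibition), compound 1 gives 3% and compound 2 gives 32%. The change ethyl in place of hydrogen on a saturated chain carbon bound to an oxygen next to a carbonyl group produced a number 29 percentage points higher from compound 1 to compound 2 (beyond the scatter). In this assay compound 3 gives 1%, a number within the scatter of that of compound 1. Compound 4 carries the same change, (ethyl in place of hydrogen on a saturated chain carbon bound to an oxygen next to a carbonyl group), on the core of compound 3, and has not yet been measured in this assay. Because compound 3 sits at 1% and the earlier step was a number 29 percentage points higher from compound 1 to compound 2 (beyond the scatter), compound 4 is expected to show a number 25 percentage points higher from compound 3 to compound 4 (beyond the scatter). Among the measured compounds shown here, compound 4 is therefore estimated at 26%, within a range from 5% to 50%; the width reflects that only one earlier instance of this change is measured.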

Compound 4, a percentage reported as inhibition, at one concentration (the size of the read-out at that concentration, not a potency): 10%
The estimate for compound 4 lay 16 percentage points above the measured number, and the stated range covers the measured number.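

Going from methoxycarbonyl to propoxycarbonyl on the core of compound 3 gave a number 9 percentage points higher from compound 3 to compound 4 (within the scatter) in this assay. The size of this step therefore did not carry over from one core to the other: the same change on two cores in this assay, a number 29 percentage points higher (beyond the scatter) from compound 1 to compound 2 and a number 9 percentage points higher (within the scatter) from compound 3 to compound 4, 20 percentage points apart, beyond the scatter of two such steps This rests on a single pair on each core, so it shows that the step depends on the core in these two cases, but it does not show what in the cores accounts for the gap or how the change would behave on a further core.

The compounds shown leave open how a longer chain such as butyl, or a branched chain such as isopropyl, would read on either core. They also leave open what an amine at the end of the chain would do.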